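The source may report more compounds than this note shows. Statements on the series, on what has been measured and on what is new or still open speak of the compounds shown alone.

Compound 1, `CC(C(=O)N1CCN(c2ccccc2)CC1)N1C(=O)CCC1=O`, gives 0% in a functional assay on the whole organism (strain Swiss) with Mus musculus as the target, in the maximal electroshock model, with a stated time of 2 h, at a dose of 300 mg/kg by the intraperitoneal route; a higher number here means a stronger effect of the compound at the dose given, a lower number a weaker effect.
Compound 2, `CC(C(=O)N1CCN(c2cccc(C(F)(F)F)c2)CC1)N1C(=O)CCC1=O`, gives 100% in this assay.

Within the data shown here, compound 2 stands at the top of the two numbers measured so far; its only neighbour is compound 1, and the step of a number 100 percentage points higher from compound 1 to compound 2 (beyond the scatter) lies beyond the scatter. Compound 3, `Cc1cccc(N2CCN(C(=O)C(C)N3C(=O)CCC3=O)CC2)c1`, has not yet been measured. It differs from compound 2 in one place: methyl in place of trifluoromethyl on an aromatic carbon. Among the measured compounds shown here, the single measured step that bears on this position is the one from compound 1 to compound 2, where a number 100 percentage points higher from compound 1 to compound 2 (beyond the scatter). That step shows that a group at this aromatic carbon matters greatly, but it compares trifluoromethyl only with hydrogen; nothing measured shows how methyl behaves there. Methyl is one heavy atom against four, so a step downward from compound 2 is expected, though probably not one that brings compound 3 back to the level of compound 1. For compound 3 the expected change is a number 33 percentage points lower from compound 2 to compound 3 (beyond the scatter). Compound 3 is therefore estimated at 67%, within a range from 17% to 100%.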

Compound 3, a percentage reported as activity, at one dose (the size of the read-out at that dose, not a potency): 0%
For compound 3 the middle estimate is 67 percentage points above the measured one, and the stated range ends above it.
By their numbers in this assay, from the lowest: compounds 1 and 3 (each within the scatter of the next); then compound 2.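

Putting methyl in place of trifluoromethyl on this aromatic carbon gives a number 100 percentage points lower from compound 2 to compound 3 (beyond the scatter) in this assay, so the earlier gain does not come with just any group at this position and the identity of the group decides the outcome. Methyl in place of hydrogen gives no change at the digits printed from compound 1 to compound 3 (within the scatter), which means that of the two groups shown on this carbon, only trifluoromethyl separates from the unsubstituted compound 1 at the dose given. Nothing available on these compounds explains why the two groups part so sharply.

The compounds shown leave open whether a chlorine atom or a methoxy group on this same carbon would stand with trifluoromethyl or with methyl, and so how far the result extends beyond this one pair of groups. They also leave open whether trifluoromethyl would give a comparable read-out on another carbon of the ring, and whether compound 1 and compound 3 would remain indistinguishable at any other dose or time.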